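The source may report more compounds than this note shows. Statements on the series, on what has been measured and on what is new or still open speak of the compounds shown alone.

Working notes on the series around the shared core of compound 1 `Cn1cnc2c(N3CCCCC3)nc(-c3ccccc3O)nc21`. In an assay on cells for displacement of a labelled ligand from adenosine receptor A1 (Homo sapiens), read by scintillation counting and radioligand binding, with a stated time of 60 min, tested at 10 uM (on this read-out higher numbers stand for more inhibition at the one concentration tested (going by the name of the read-out) and lower numbers for less inhibition), compound 1 gives 50.5%. Compound 2 `CN1CCN(c2nc(-c3ccc(Cl)c(C(F)(F)F)c3)nc3[nH]cnc23)CC1` gives 52.4% in this assay. Compound 3 `CN1CCN(c2nc(-c3ccccc3O)nc3c2ncn3C)CC1` in this assay returns only a limit of the assay, > 80%. Of the two compounds with a number, compound 1 stands lowest, with compound 2 nearest at a gap that lies within the scatter; the third value sits at the limit of > 80% in this assay, at which 1 of the 3 values shown sits, and is a limit rather than a number. For the measured compounds named here, the only step with a single change is a number at least 29.5 percentage points higher from compound 1 to compound 3 (beyond the scatter), the exchange of piperidin-1-yl for 4-methylpiperazin-1-yl.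

Compound 4 `Cn1cnc2c(N3CCCCC3)nc(-c3cccc(Cl)c3)nc21` carries 3-chlorophenyl in place of 2-hydroxyphenyl on an aromatic carbon. Going by the values given here, no measured step touches the aryl group alone: compound 2 carries another aryl but differs from compound 1 in more than one place, so its value only shows where it lands, and the step to compound 3 concerns the piperidin-1-yl group, not the aryl. With nothing that bears directly on the change, compound 4 is expected to remain close to compound 1, the expected step of a number 5.5 percentage points lower from compound 1 to compound 4 (within the scatter) not beyond the scatter. The estimate for compound 4 is 45%, expected within 20% to 72%.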

Compound 4, a percentage reported as inhibition, at one concentration (the size of the read-out at that concentration, not a potency): 22.4%
Compound 4: middle estimate off by 22.6 percentage points, on the high side; the range from low to high includes it.
By their numbers in this assay, from the lowest: compound 4; then compounds 1 and 2 (each within the scatter of the next). At a limit, above all of these: compound 3.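

In this assay, the exchange of 2-hydroxyphenyl for 3-chlorophenyl on the aromatic carbon between two ring nitrogen atoms gives a number 28.1 percentage points lower from compound 1 to compound 4 (beyond the scatter), so the aryl group at this position affects the read-out with the piperidin-1-yl group held constant, which the earlier single-change step, confined to the piperidin-1-yl group, could not show. The exchange swaps a group with 1 hydrogen-bond donor and 1 hydrogen-bond acceptor for one with neither, at the same count of heavy atoms, and it moves the substituent on the aryl ring as well as replacing it. Nothing measured here gives a reason for this step.

The pair cannot separate the loss of the hydroxyl group from the arrival of the chlorine or from the shift in its place on the ring, and a plain phenyl, 2-chlorophenyl or 3-hydroxyphenyl group would be needed to divide these effects. Also open, on these data alone, is whether the same aryl exchange would carry over to the 4-methylpiperazin-1-yl series of compound 3, whose reading in this assay is a limit of the assay.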